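The compounds below may be only part of what the source reports. "The series", "measured", "known", "first", "only" and "open" are said of these compounds alone.

Working notes on the series. Going by the values given here, in an assay on microsomes from liver with sterol O-acyltransferase 1 (Rattus norvegicus) as the target (on this read-out higher numbers stand for weaker inhibition and lower numbers for stronger inhibition), compound 2 `CCCCCCCN(CCCCCSc1nc(-c2ccc(N(C)C)cc2)c(-c2ccc(N(C)C)cc2)[nH]1)C(=O)NC(C)C` gives 80 nM, the only number in hand. Among the compounds with values here, compound 1 `COCCOCCN(CCCCCSc1nc(-c2ccc(N(C)C)cc2)c(-c2ccc(N(C)C)cc2)[nH]1)C(=O)NC(C)C` is recorded as "not active" (no number reported) in this assay, so no step between measured compounds can be drawn. Compound 3 `CCCCCCCN(CCCCCSc1nc(-c2ccc(N(C)C)cc2)c(-c2ccc(N(C)C)cc2)[nH]1)C(=O)CC1CCCCC1` is not yet measured; it differs from compound 2 by cyclohexylmethyl in place of isopropylamino on a carbonyl carbon. Within the data shown here, no measured step covers such a change, so the expected shift a 1.3-fold higher number from compound 2 to compound 3 (0.10 log units; within the scatter) is small, within or near the scatter, in no firm direction. Compound 3 is estimated at 100 nM, range 30 nM to 400 nM.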

Compound 3, half-maximal inhibitory concentration: 50 nM
The estimate for compound 3 lay 2.0-fold (0.30 log units) above the measured number; low and high end bracket the measured number.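

In this assay, cyclohexylmethyl in place of isopropylamino on a carbonyl carbon gives a 1.6-fold lower number from compound 2 to compound 3 (0.20 log units; within the scatter), so compounds 2 and 3 cannot be told apart. A number in this range therefore does not depend on the amide-type hydrogen-bond donor of isopropylamino, and this position accepts a six-membered non-aromatic ring of carbon only. No evidence in hand gives a reason for this result.

Still open, from the compounds shown here alone, is what a carboxylic acid or a basic amine would do on this carbonyl carbon. Also open, going by these compounds, is whether a longer straight chain would serve as well as the ring.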